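The compounds below may be only part of what the source reports. "The series", "measured", "known", "first", "only" and "open" are said of these compounds alone.

Among the measured compounds shown here, in a functional assay on KB cells (Homo sapiens) for inhibition, read by sulforhodamine B assay (a lower number here means a stronger inhibitor of growth, a higher number a weaker inhibitor of growth), compound 1 `FC(F)(F)c1ccc(-c2ccc(-c3ccc(-c4nc5ccccc5[nH]4)cc3)cc2)cc1` gives 47200 nM and compound 2 `FC(F)(F)Oc1ccc(-c2ccc(-c3ccc(-c4nc5ccccc5[nH]4)cc3)cc2)cc1` gives 39100 nM, so compound 1 stands level with its only measured neighbour. Compound 3 `COc1ccc(-c2ccc(-c3ccc(-c4nc5ccccc5[nH]4)cc3)cc2)cc1OC` differs from compound 1 as follows: 3,4-dimethoxyphenyl in place of 4-(trifluoromethyl)phenyl on an aromatic carbon. For the measured compounds named here, only one measured step bears on this change, trifluoromethoxy in place of trifluoromethyl, and it gave a 1.2-fold lower number from compound 1 to compound 2 (0.08 log units; within the scatter). That step leaves the dimethoxy pattern untested, so the expectation is weak, and no step beyond the scatter is expected in this assay. The expected change is a 1.5-fold lower number from compound 1 to compound 3 (0.17 log units; within the scatter). For compound 3 the estimated value is 32000 nM, with an expected range of 11000 nM to 70000 nM.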

Compound 3, concentration for 50% growth inhibition: 9250 nM
For compound 3 the middle estimate is 3.5-fold (0.54 log units) above the measured one; measured number below the stated range.
By their numbers in this assay, from the lowest: compound 3; then compounds 2 and 1 (each within the scatter of the next).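

On an aromatic carbon para to a large group, the terminal ring can shift the growth-inhibition number by more than the scatter. In this assay, 3,4-dimethoxyphenyl in place of 4-(trifluoromethyl)phenyl gives a 5.1-fold lower number from compound 1 to compound 3 (0.71 log units; beyond the scatter), whereas the earlier trifluoromethoxy change did not leave the scatter. The entering group counts two hydrogen-bond acceptors and the leaving group none, but nothing available ties this step to that difference or to any other feature of the change.

As far as these compounds go, whether a single methoxy group would give the same step remains open. So does the reading for an amine or a carboxylic acid on this ring.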